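Swapping a Pyridine Attachment Point on a Cytotoxic Core

The compounds below may be only part of what the source reports. "The series", "measured", "known", "first", "only" and "open" are said of these compounds alone.

Three compounds sharing a double-bonded, nitrogen-containing ring core with two aromatic arms have been tested in a functional assay on HepG2 cells (Homo sapiens) for cytotoxicity, read by MTT assay, with a stated time of 24 h; on this read-out lower numbers stand for stronger inhibition and higher numbers for weaker inhibition. Compound 1 `COc1cc(/C=C2\CN(C)C/C(=C\c3cccnc3)C2=O)cc(OC)c1` carries a pyridin-3-yl arm and a dimethoxyphenyl arm; in this assay compound 1 gives 6910 nM. Compound 3 `COc1cc(/C=C2\CN(C)C/C(=C\c3ccncc3)C2=O)cc(OC)c1` keeps the same core and the dimethoxyphenyl arm but differs by pyridin-4-yl in place of pyridin-3-yl on a double-bonded chain carbon bound to a double-bonded ring carbon. In this assay compound 3 gives 9500 nM, and the step of a 1.4-fold higher number from compound 1 to compound 3 (0.14 log units; within the scatter) shows that this swap left the read-out essentially unchanged. Compound 2 `CN1C/C(=C\c2cccnc2)C(=O)/C(=C/c2ccccc2F)C1` has the pyridin-3-yl arm of compound 1 but a fluorophenyl arm in place of the dimethoxyphenyl arm; the difference between the two cores is not broken down here. In this assay compound 2 gives 4810 nM, a number within the scatter of both compound 1 and compound 3.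

Compound 4 `CN1C/C(=C\c2ccncc2)C(=O)/C(=C/c2ccccc2F)C1` has not yet been measured. It is related to compound 2 by pyridin-4-yl in place of pyridin-3-yl on a double-bonded chain carbon bound to a double-bonded ring carbon, the same change, at the same place, that turns compound 1 into compound 3. Because that earlier step a 1.4-fold higher number from compound 1 to compound 3 (0.14 log units; within the scatter) stayed within the scatter, a similarly small shift is expected here, with the step from compound 2 to compound 4 estimated at a 1.4-fold higher number from compound 2 to compound 4 (0.14 log units; within the scatter). Compound 4 is therefore expected to give about 6700 nM in this assay, most likely between 3000 nM and 15000 nM.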

Compound 4, half-maximal inhibitory concentration: 4600 nM
Beside the measured number, compound 4's estimate is 1.5-fold (0.16 log units) above it, and the stated range covers the measured number.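

In this assay, the new step is a 1.0-fold lower number from compound 2 to compound 4 (0.02 log units; within the scatter), so on the core of compound 2, which carries the fluorophenyl arm, pyridin-4-yl in place of pyridin-3-yl gives no change that stands out from the scatter. The same change on the core of compound 1, which carries the dimethoxyphenyl arm, also stayed within the scatter, and the two steps do not differ: the same change on two cores in this assay, a 1.4-fold higher number (0.14 log units; within the scatter) from compound 1 to compound 3 and a 1.0-fold lower number (0.02 log units; within the scatter) from compound 2 to compound 4, 1.4-fold (0.16 log units) apart, within the scatter of two such steps. For these two pairs in this one read-out, the swap therefore carries over from one core to the other as a change too small to detect, but this does not show that it would stay as small with other arms, and two steps this small cannot reveal any real but slight difference between the cores.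

The compounds shown leave open whether an arm of a different kind on the double-bonded chain carbon, such as a plain phenyl ring or a ring bearing an amine or a carboxylic acid, would move the number beyond the scatter. They also leave open whether the silence of this swap holds in other cell types or over other exposure times.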